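This account rests on a few compounds, and the source may have more. Where it says the series, first, only, none or still open, it means among the compounds named here.

Measured in a functional assay on KB cells (Homo sapiens) for inhibition; on this read-out higher numbers stand for weaker inhibition and lower numbers for stronger inhibition:
- Compound 1 `Nc1nc2c(Cl)cc(Cl)cc2n1C1O[C@H](CO)[C@@H](O)[C@H]1O`: > 300000 nM, a limit
- Compound 2 `OC[C@H]1OC(n2c(S)nc3c(Cl)cc(Cl)cc32)[C@H](O)[C@@H]1O`: > 300000 nM, a limit

Compound 2 offers no number to build on. In this assay compound 2 gives > 300000 nM, which is a limit and not a measured potency. Its position is shared, as the limit of > 300000 nM in this assay, at which 2 of the 2 values shown sit, shows, so nothing separates it from compound 1.

Compound 3 `OC[C@H]1OC(n2c(SCc3ccccc3)nc3c(Cl)cc(Cl)cc32)[C@H](O)[C@@H]1O` follows from compound 2 by one change, benzyl in place of hydrogen on a sulfur.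

Among the compounds with values here, only one measured step lies close to this change: a step that the two limits leave unreadable from compound 1 to compound 2. That step concerns the group on an aromatic carbon, not benzyl on the sulfur, and it has no readable size. The data therefore set no size for the new step, and the expectation is only tentative: a modest move towards stronger inhibition, with another limit reading quite possible.

The estimated at least 3.0-fold lower number from compound 2 to compound 3 (0.47 log units; beyond the scatter) carries that expectation in numbers. For compound 3 the expected value is 100000 nM, with an estimated range of 25000 nM to 300000 nM.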

Compound 3, half-maximal inhibitory concentration: 122000 nM
Beside the measured number, compound 3's estimate is 1.2-fold (0.09 log units) below it, and the stated range covers the measured number.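

Benzyl on the sulfur shows an at least 2.4-fold lower number from compound 2 to compound 3 (0.39 log units; beyond the scatter) and so gives, in this assay, the only reading among these compounds that is a number and not a limit. Measured against the amino compound, the change to benzylsulfanyl on the aromatic carbon shows an at least 2.4-fold lower number from compound 1 to compound 3 (0.39 log units; beyond the scatter) and so establishes that this position can carry a large group and still move the read-out towards stronger inhibition, something the unreadable step between the two earlier compounds could not show. Both new steps keep an open upper size, since each starts from a limit, and the true distance from compound 3 to either neighbour stays unknown: the limit of > 300000 nM in this assay, at which 2 of the 3 values shown sit.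

The compounds shown leave open whether the change depends on the aromatic ring of the benzyl group or whether a plain methyl or a longer chain on the sulfur would move the number as far. They also leave open whether a benzyl ring carrying a chlorine, an amine or a carboxylic acid would take the read-out further from the limit or back towards it.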